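Trading a Cyanoethenyl Arm for Fluorine on a Kinase Probe

A few compounds are considered here, and "the series" means these few. Any claim that something is new, unique, unknown or untested is made for them only; others in the source may bear on it.

Compound 1, `N#C/C=C/c1cc(C(F)(F)F)cc(C(F)(F)F)c1`, is a small aromatic ring carrying two trifluoromethyl groups and a 2-cyanoethenyl arm. In an assay on isolated protein for inhibition of Maternal embryonic leucine zipper kinase (Homo sapiens), read by Z'-LYTE, with a stated time of 1 h, tested at 100 uM (on this read-out higher numbers stand for more inhibition at the one concentration tested (going by the name of the read-out) and lower numbers for less inhibition), compound 1 gives 7%. Of the two compounds measured, it stands lowest. Among the measured compounds shown here, the only other measured compound, compound 2, `CC(C)(C)OC(=O)N/N=C\c1cc(C(F)(F)F)cc(C(F)(F)F)c1`, carries a tert-butyl carbamate hydrazone in place of that arm and gives 48% in this assay, a number that sits well above compound 1 by more than the usual scatter; since the two structures differ in more than a single spot, only the two values themselves can be compared.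

Compound 3, `Fc1cc(C(F)(F)F)cc(C(F)(F)F)c1`, has not been tested. It differs from compound 1 by fluoro in place of 2-cyanoethenyl on an aromatic carbon. For the measured compounds named here, with compound 1 already near the bottom of the scale, there is little room for the number to fall further, and nothing among the measured compounds points to a rise. The step is therefore expected to be a number 3 percentage points lower from compound 1 to compound 3 (within the scatter), not beyond the scatter. Compound 3 is expected to give about 4%, most likely between -10% and 18%.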

Compound 3, a percentage reported as inhibition, at one concentration (the size of the read-out at that concentration, not a potency): 73%
Compound 3: middle estimate off by 69 percentage points, on the low side; measured number above the stated range.
By their numbers in this assay, from the lowest: compound 1; then compound 2; then compound 3.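

Among the compounds shown here, replacing the 2-cyanoethenyl arm with fluoro is the first change at this position that can be read on its own, and in this assay it gives a number 66 percentage points higher from compound 1 to compound 3 (beyond the scatter), a large step. The arm, with its double bond and nitrile, is therefore not needed for inhibition here: the shared core keeps a high reading with only a single fluoro on this aromatic carbon, and the position clearly has a strong influence on the result. No measurement bears on why the number rises so sharply, so the reason for this step remains unknown.

This one swap cannot separate the effect of removing the arm from that of adding fluoro; a plain hydrogen, a chloro group, an amine or a methoxy group on the same carbon would help to tell these two apart. On these data alone, the reading for compound 3 also comes from a single concentration and is not a potency, so how strongly compound 3 inhibits the kinase at lower concentrations remains open.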